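Pentyl in place of hydroxypropylsulfanyl on the benzyl ring

The compounds below may be only part of what the source reports. "The series", "measured", "known", "first", "only" and "open" are said of these compounds alone.

Working notes on a small series tested in an assay on CHO cells for antagonist activity at transient receptor potential cation channel subfamily V member 1 (Homo sapiens), read by FLIPR; a higher number here means a weaker inhibitor, a lower number a stronger inhibitor. Compound 1 `CC(C(=O)NCc1ccc(C(F)(F)F)cc1OCc1ccc(F)cc1)c1ccc(NS(C)(=O)=O)c(F)c1` carries a (4-fluorophenyl)methoxy group on the benzylic ring and in this assay compound 1 gives 0.5 nM. Compound 2 `CC(C(=O)NCc1ccc(C(F)(F)F)cc1SCCCO)c1ccc(NS(C)(=O)=O)c(F)c1` bears a (3-hydroxypropyl)sulfanyl group at that position instead; in this assay compound 2 gives "not active" (no number reported), so compound 2 stands without a number among the results shown and cannot be placed against compound 1 beyond the fact that it registered no activity. Compound 3 `CCCCCc1cc(C(F)(F)F)ccc1CNC(=O)C(C)c1ccc(NS(C)(=O)=O)c(F)c1` is compound 2 altered in one place: pentyl in place of (3-hydroxypropyl)sulfanyl on an aromatic carbon. For the measured compounds named here, no measured pair matches this change, so the size of the step is open; a gain beyond the scatter is expected, given that compound 2 gives "not active" (no number reported) and the shared core with a hydrocarbon-bearing ring in compound 1 gives 0.5 nM. For compound 3 in this assay an estimated 20 nM is expected, within a range of 2 nM to 300 nM.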

Compound 3, inhibition constant: 0.4 nM
The estimate for compound 3 lay 50-fold (1.70 log units) above the measured number, outside the stated range (below it).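

In this assay this position accepts an unbranched hydrocarbon chain with no ring and no oxygen link: the change to pentyl gives a 1.3-fold lower number from compound 1 to compound 3 (0.10 log units; within the scatter). Compound 2 has no number, so the step from compound 2 to compound 3 cannot be read as a size, but it shows that the count of 5 heavy atoms, shared by pentyl and (3-hydroxypropyl)sulfanyl, does not alone separate an inactive compound from an active one. Nothing measured here accounts for the difference between these two groups.

The sulfur link and the terminal hydroxyl leave together in this change, so the compounds shown do not assign the inactivity of compound 2 to either one. As far as these compounds go, a pentylsulfanyl group or a 5-hydroxypentyl chain at this position would separate the two, and how far the position tolerates a shorter chain such as ethyl remains open.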